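Longer Chain on the Fluorinated Analog: What to Expect

The compounds below may be only part of what the source reports. "The series", "measured", "known", "first", "only" and "open" are said of these compounds alone.

Compound 1 `CN(C)C(=O)c1cc2cnc(Nc3ccc(C(=O)NCCCCN=C=S)cc3)nc2n1C1CCCC1` gives 74.2% in a functional assay on NCI-H1299 cells (Homo sapiens) for inhibition, read by CCK-8 assay, with a stated time of 72 h, tested at 10 uM; a higher number here means a stronger effect of the compound at the concentration tested, a lower number a weaker effect.
Compound 2 `CN(C)C(=O)c1cc2cnc(Nc3ccc(C(=O)NCCCCCN=C=S)cc3)nc2n1C1CCCC1` gives 76.5% in this assay.
Compound 3 `CN(C)C(=O)c1cc2cnc(Nc3ccc(C(=O)NCCCCCCN=C=S)cc3F)nc2n1C1CCCC1` gives 77.6% in this assay.

Compound 1 and compound 2 share a core and differ only by a group of 4 heavy atoms (2 carbon, 1 nitrogen, 1 sulfur; no ring) in place of a group of 3 heavy atoms (1 carbon, 1 nitrogen, 1 sulfur; no ring), on a saturated chain carbon, four bonds along the chain from an amide-type nitrogen. This change made a step of a number 2.3 percentage points higher from compound 1 to compound 2 (within the scatter), so the two values sit within the usual scatter of each other and no order between them can be read.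

Compound 3 carries a different core; the difference between the core of compound 3 and the core of compound 1 is not broken down here. Compound 4 `CN(C)C(=O)c1cc2cnc(Nc3ccc(C(=O)NCCCCCCCN=C=S)cc3F)nc2n1C1CCCC1` is not yet measured. It differs from compound 3 by a group of 4 heavy atoms (2 carbon, 1 nitrogen, 1 sulfur; no ring) in place of a group of 3 heavy atoms (1 carbon, 1 nitrogen, 1 sulfur; no ring), on a saturated chain carbon, six bonds along the chain from an amide-type nitrogen. The place is not word for word the same as before: the chain carbon now lies six bonds along the chain from the amide-type nitrogen instead of four, so this is the same kind of change, not the same change.

Because the earlier step of a number 2.3 percentage points higher from compound 1 to compound 2 (within the scatter) stayed within the scatter, the step from compound 3 to compound 4 is expected to be small as well, about a number 1.4 percentage points higher from compound 3 to compound 4 (within the scatter). Compound 4 is therefore estimated at 79% in this assay, expected between 70% and 87%.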

Compound 4, a percentage reported as inhibition, at one concentration (the size of the read-out at that concentration, not a potency): 35.8%
Beside the measured number, compound 4's estimate is 43.2 percentage points above it, outside the stated range (below it).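

In this assay, lengthening the chain on the core of compound 3 gave a very different outcome than the earlier lengthening, with a step of a number 41.8 percentage points lower from compound 3 to compound 4 (beyond the scatter). This shows that, in this series, the size and even the direction of this change did not carry over from one core to the other: the same change on two cores in this assay, a number 2.3 percentage points higher (within the scatter) from compound 1 to compound 2 and a number 41.8 percentage points lower (beyond the scatter) from compound 3 to compound 4, 44.1 percentage points apart, beyond the scatter of two such steps

It does not show why, as the two steps differ both in their core and in their place on the chain, six bonds rather than four from the amide-type nitrogen, and a single pair on each core cannot separate these differences or set a general rule.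

Still open, as far as these compounds go, is what the chain of compound 4 would give on the core of compound 1, a result that could help separate the role of the core from that of chain length. Also open, from the compounds shown here alone, is whether a still longer chain, or an amine at the chain end in place of the present end group, would stay near compound 4 or come closer to compound 3.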